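The source may report more compounds than this note shows. Statements on the series, on what has been measured and on what is new or still open speak of the compounds shown alone.

In a functional assay on KB cells (Homo sapiens) for antiproliferative activity, read by MTT assay, with a stated time of 72 h (a lower number here means a stronger inhibitor, a higher number a weaker inhibitor), compound 1 (`CCOC(=O)c1cc(-c2cc(OC)c(OC)c(OC)c2)c(-c2ccc(OC)cc2)s1`) gives 13200 nM. Compound 3 (`CCOC(=O)c1cc(-c2cc(OC)c(OC)c(OC)c2)c(-c2ccc3ccccc3c2)s1`) gives 5890 nM, so compound 1 holds the higher of the two numeric values, with compound 3 nearest. Compound 2 (`CCOC(=O)c1cc(-c2cc(OC)c(OC)c(OC)c2)c(-c2cccc(Br)c2)s1`) reads > 100000 nM, which is a limit of the assay.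

The change to compound 4 (`CCOC(=O)c1cc(-c2cc(OC)c(OC)c(OC)c2)c(-c2ccc(OC)c(OCc3ccccc3)c2)s1`) is benzyloxy in place of hydrogen on an aromatic carbon. The benzyloxy group replaces hydrogen on an aromatic carbon, ortho to a methoxy group and meta to a large group.

Two measured steps replace the 4-methoxyphenyl group of compound 1 and so bear on this change: a 2.2-fold lower number from compound 1 to compound 3 (0.35 log units; beyond the scatter) and an at least 7.5-fold higher number from compound 1 to compound 2 (0.87 log units; beyond the scatter). They run in opposite directions, and neither introduces benzyloxy. With compound 3 pointing one way and compound 2 the other, no step beyond the scatter is expected in this assay, though a loss remains possible. The expected change is a 1.2-fold higher number from compound 1 to compound 4 (0.08 log units; within the scatter). Compound 4 is estimated at 16000 nM, with an expected range of 4000 nM to 60000 nM.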

Compound 4, half-maximal inhibitory concentration: > 100000 nM
Compound 4: only a limit was reported (the forecaster's own chance of this, stated with the estimate: 20%); middle value at least 6.2-fold (0.79 log units) from the limit.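

Unlike the earlier steps, which swap the whole 4-methoxyphenyl group, this change keeps that group and adds benzyloxy on an aromatic carbon, ortho to a methoxy group, giving an at least 7.5-fold higher number from compound 1 to compound 4 (0.87 log units; beyond the scatter) in this assay. Compound 4 reads > 100000 nM, which is a limit of the assay and not a number, so the step gives a minimum size only. A single added group at this place is thus enough to take the series from a measurable value to the limit, where compound 2 also sits: the limit of > 100000 nM in this assay, at which 2 of the 4 values shown sit.

On these data alone, whether the loss belongs to benzyloxy itself or to any substituent on this carbon stays open; a hydroxy group, a fluorine or an amine at the same place would separate the two. Compound 2 and compound 4 cannot be ranked against each other, as both are limits.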